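A few compounds are considered here, and "the series" means these few. Any claim that something is new, unique, unknown or untested is made for them only; others in the source may bear on it.

Measured compounds:

Compound 1 `Cc1nccn1-c1cnc(NCc2c(F)ccc3c2CCO3)c2cn[nH]c(=O)c12`: 2.1
Compound 2 `O=C(Nc1cnc(NCc2c(F)ccc3c2CCO3)n2cnnc12)c1ccccc1`: 3
Compound 3 `Cc1ncccc1-c1cnc(NCc2c(F)ccc3c2CCO3)c2n[nH]c(=O)n12`: 2.5

These three compounds were examined in a physicochemical assay for lipophilicity, using the shake flask method, in phosphate buffer, measured as octanol-water partition, with a stated time of 30 min, at pH 7.4; on this read-out higher numbers stand for higher lipophilicity and lower numbers for lower lipophilicity. Compound 1 gives the lowest of the three numbers, 2.1. The nearest to it is compound 3, which in this assay gives 2.5, a gap beyond the usual scatter. The furthest is compound 2, which in this assay gives 3, also a gap beyond the scatter. The three compounds differ from one another in more than one place, so no single change can be tied to any of these gaps.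

Compound 4 `Cc1nc(CN(C)C)ccc1-c1cnc(NCc2c(F)ccc3c2CCO3)c2cn[nH]c(=O)c12` has not yet been measured. It differs from compound 1 in one place: 6-((dimethylamino)methyl)-2-methylpyridin-3-yl in place of 2-methyl-1H-imidazol-1-yl on an aromatic carbon. For the measured compounds named here, the entering group is larger than the leaving one and carries a dimethylaminomethyl arm, and no pair of measured compounds shows this change alone, so no measured step guides the expectation. The step from compound 1 to compound 4, a number 0.10 log units lower from compound 1 to compound 4 (within the scatter), is expected to be small, within or close to the scatter, with no clear direction. Compound 4 is therefore estimated at 2, within a range from 1.2 to 2.8.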

Compound 4, distribution coefficient: 2
Estimate against measurement, compound 4: no gap at the digits printed; the range from low to high includes it.
By their numbers in this assay, from the lowest: compounds 4 and 1 (each within the scatter of the next); then compound 3; then compound 2.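

In this assay, for the compounds shown here, the change from 2-methyl-1H-imidazol-1-yl to 6-((dimethylamino)methyl)-2-methylpyridin-3-yl gives the first step in this set that can be tied to a single place: a number 0.10 log units lower from compound 1 to compound 4 (within the scatter) on this read-out. Going by these compounds alone, on this aromatic carbon of the core of compound 1, a group of 6 heavy atoms with a five-membered aromatic ring gives way to one of 11 heavy atoms with a six-membered aromatic ring and a dimethylaminomethyl arm, and the two compounds still cannot be told apart beyond the scatter, something the earlier compounds, which differ in more than one place, could not show. Nothing measured here accounts for this outcome, so no cause can be given for it.

The compounds shown leave open whether the 2-methylpyridin-3-yl group without the dimethylaminomethyl arm would, on the core of compound 1, read the same as compound 4. Going by these compounds, the read-out with a carboxylic acid in place of the dimethylamino end of that arm is likewise open.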